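Methyl for Fluoro on a Shared Core

The source may hold more compounds than are shown below. What is called first, only, known or untested is meant among the compounds shown, and "the series" means these compounds.

Compound 1 `Cc1ccc2c(=O)cc(-c3ccc(F)cc3)oc2c1` was tested in an in vitro assay on BTI-TN-5B1-4 cells for inhibition of Amine oxidase [flavin-containing] B (Homo sapiens), tested at 100 uM (a lower number here means less inhibition, a higher number more inhibition at the concentration tested (going by the name of the read-out)), and gave 40%. Compound 2 `COc1ccc2c(=O)cc(-c3ccccc3)oc2c1` gave 40% in this assay. Compound 1 therefore stands level with compound 2 at the digits shown, the two values lying within the usual scatter of each other. Compound 3 `Cc1ccc(-c2cc(=O)c3ccc(C)cc3o2)cc1` has not yet been measured in this assay. It differs from compound 1 by methyl in place of fluoro on an aromatic carbon. Within the data shown here, since no measured step is available, the change is expected to move the read-out by no more than the scatter, in no particular direction. The result for compound 3 is thus estimated at 40%, with a range from 25% to 55%. This expectation corresponds to a step of no change at the digits printed from compound 1 to compound 3 (within the scatter).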

Compound 3, a percentage reported as inhibition, at one concentration (the size of the read-out at that concentration, not a potency): 40%
Beside the measured number, compound 3's estimate shows no gap at the digits printed; the range from low to high includes it.
By their numbers in this assay, from the lowest: compounds 1, 2 and 3 (each within the scatter of the next).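

In this assay, among these compounds, methyl in place of fluoro on an aromatic carbon, para to a large group, gives no change at the digits printed from compound 1 to compound 3 (within the scatter) as the first measured step on the shared core. At the single concentration tested, the read-out therefore does not separate these two groups at this position, although nothing measured here speaks to the reason. The compounds shown leave open whether an amine, a carboxylic acid or a longer chain in this place would move the read-out. They also leave open whether methyl and fluoro would remain level in a full potency measurement.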